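Swapping Cyclohexyl for 2-Chlorophenyl in an Antiproliferative Series

The source may hold more compounds than are shown below. What is called first, only, known or untested is meant among the compounds shown, and "the series" means these compounds.

Going by the values given here, in a functional assay on HCT-116 cells (Homo sapiens) for antiproliferative activity, read by MTT assay, with a stated time of 72 h (on this read-out lower numbers stand for stronger inhibition and higher numbers for weaker inhibition), compound 1 `Nc1nc(N)c2cc(CSC(=S)N3CCN(C4CCCCC4)CC3)ccc2n1` gives 8400 nM, the higher of the two numbers known so far. Among the compounds with values here, the only other measured compound, compound 2 `Nc1nc(N)c2cc(CSC(=S)N3CCN(c4ccccc4)CC3)ccc2n1`, gives 4120 nM. Within the data shown here, putting phenyl in place of cyclohexyl on an amine nitrogen in a ring is the single measured step here: a 2.0-fold lower number from compound 1 to compound 2 (0.31 log units; beyond the scatter). It is modest, but beyond the usual scatter.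

Compound 3 `Nc1nc(N)c2cc(CSC(=S)N3CCN(c4ccccc4Cl)CC3)ccc2n1` has not been measured yet. It differs from compound 1 at that same place, with 2-chlorophenyl in place of cyclohexyl on an amine nitrogen in a ring. Among the measured compounds shown here, the entering group also brings an aromatic ring, but no measured compound here shows what the chlorine does. For the measured compounds named here, the step to compound 2 is therefore the only guide, and a change of similar size in this assay, toward a lower number, is expected. The estimated change is a 2.4-fold lower number from compound 1 to compound 3 (0.38 log units; beyond the scatter). For compound 3 the expected value is 3500 nM, within an estimated range of 1500 nM to 8000 nM.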

Compound 3, half-maximal inhibitory concentration: 5490 nM
The estimate for compound 3 lay 1.6-fold (0.20 log units) below the measured number, and the stated range covers the measured number.
By their numbers in this assay, from the lowest: compounds 2, 3 and 1 (each within the scatter of the next, the first and the last beyond it).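

In this assay, 2-chlorophenyl in place of cyclohexyl on the amine nitrogen in the ring gives a 1.5-fold lower number from compound 1 to compound 3 (0.18 log units; within the scatter), so this swap, unlike the one to plain phenyl, cannot be told apart from the differences seen between repeated measurements. Adding the chlorine to the phenyl ring gives a 1.3-fold higher number from compound 2 to compound 3 (0.12 log units; within the scatter), so chloro in place of hydrogen on this aromatic carbon also has no effect that can be read here. Compound 3 therefore lies within the scatter of both compound 1 and compound 2, even though those two lie beyond the scatter of each other.

Going by these compounds, whether a methoxy group or a carboxylic acid in place of the chlorine, or a benzyl group in place of 2-chlorophenyl, would give a number clearly apart from these remains open. Nothing measured here gives a reason for these numbers.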